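Notes on compound 3: trifluoromethyl in place of hydrogen

The source may report more compounds than this note shows. Statements on the series, on what has been measured and on what is new or still open speak of the compounds shown alone.

Compound 1 `COc1ccc(CN(C(=O)Nc2ccc(Cl)cc2)n2cnnc2)cc1OC` is known in a functional assay on MDA-MB-231 cells (Homo sapiens) for cytotoxicity, read by MTT assay, with a stated time of 48 h (a higher number here means a weaker inhibitor, a lower number a stronger inhibitor), only as a limit: compound 1 gives > 50000 nM. Compound 2 `COc1ccc(CN(C(=O)Nc2ccc(C)cc2)n2cnnc2)cc1OC` likewise reaches only a limit, giving > 50000 nM. The step that the two limits leave unreadable from compound 1 to compound 2 is therefore unreadable, both values sitting at the limit of > 50000 nM in this assay, at which 2 of the 2 values shown sit. Compound 3 `COc1ccc(CN(C(=O)Nc2ccc(Cl)c(C(F)(F)F)c2)n2cnnc2)cc1OC` differs from compound 1 by trifluoromethyl in place of hydrogen on an aromatic carbon. Within the data shown here, no measured step bears on this change, so no direction beyond the scatter can be expected. Compound 3 is estimated at 50000 nM (range 15000 nM to 200000 nM), most likely again at the limit. The expected step is a number no higher from compound 1 to compound 3 (the limit leaves the size open).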

Compound 3, half-maximal inhibitory concentration: > 50000 nM
Compound 3 ended at the assay's limit; the forecaster's own chance of this, stated with the estimate: 75%; the middle value sits exactly at the limit.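

In this assay no step can be read from compound 1 to compound 3, as both values are limits: the limit of > 50000 nM in this assay, at which 3 of the 3 values shown sit.

The compounds shown leave open whether any member of the series gives a measurable value in this assay and what trifluoromethyl in place of hydrogen changes.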